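Swapping one aromatic ring for another at the same place

A few compounds are considered here, and "the series" means these few. Any claim that something is new, unique, unknown or untested is made for them only; others in the source may bear on it.

Measured so far in a functional assay on HeLa cells (Homo sapiens) for inhibition, with a stated time of 72 h; a higher number here means a weaker inhibitor, a lower number a stronger inhibitor
Compound 1 `NC1CCC(Nc2nc(NCc3ccc(Br)cc3)c3ncn(C4CCCC4)c3n2)CC1` gives 1510 nM
Compound 2 `NC1CCC(Nc2nc(NCc3ccc(-c4cccc(F)c4)cc3)c3ncn(C4CCCC4)c3n2)CC1` gives 445 nM

Compound 2 has the lower of these two numbers, and its gap to compound 1 lies beyond the scatter, so it is the stronger inhibitor of the pair. Compound 3 `NC1CCC(Nc2nc(NCc3ccc(-c4ccsc4)cc3)c3ncn(C4CCCC4)c3n2)CC1` has not yet been measured. It keeps the shared core and changes one group: thiophen-3-yl in place of 3-fluorophenyl on an aromatic carbon, para to a large group (thiophen-3-yl in place of 3-fluorophenyl on an aromatic carbon).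

For the measured compounds named here, only one measured step bears on this place. It is a modest one (a 3.4-fold lower number from compound 1 to compound 2 (0.53 log units; beyond the scatter)), where 3-fluorophenyl took the place of bromo. Going by the values given here, that step compares an aromatic ring with a single atom, whereas compound 3 replaces one aromatic ring with another, and no measured pair tests such a swap. A small change in this assay therefore seems most likely, in either direction. The step estimated here is a 1.1-fold lower number from compound 2 to compound 3 (0.03 log units; within the scatter) and would stay within the scatter. For compound 3 the expected value is 420 nM with an estimated range from 180 nM to 1000 nM in this read-out.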

Compound 3, half-maximal inhibitory concentration: 220 nM
The estimate for compound 3 lay 1.9-fold (0.28 log units) above the measured number, within the range that was stated.
By their numbers in this assay, from the lowest: compound 3; then compound 2; then compound 1.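

In this assay, for the compounds shown here, the earlier compounds showed only that an aromatic ring at this place gives a lower number than bromo, with a 3.4-fold lower number from compound 1 to compound 2 (0.53 log units; beyond the scatter). Replacing one aromatic ring with another gives a 2.0-fold lower number from compound 2 to compound 3 (0.31 log units; beyond the scatter), so the choice of ring also matters here, not just the presence of a ring. Measured against bromo, thiophen-3-yl gives a 6.9-fold lower number from compound 1 to compound 3 (0.84 log units; beyond the scatter), a larger step than 3-fluorophenyl gave, and nothing available explains the difference between these two rings.

The swap changes several things at once: the ring goes from six-membered to five-membered, sulfur enters, and fluorine leaves, so the compounds shown cannot say which of these changes accounts for the lower number. Comparison with a plain phenyl ring, which would separate the fluorine from the ring itself, or with a furan-3-yl ring, which would put oxygen where the sulfur stands, could begin to pull these changes apart, and whether the order of the three compounds holds in other cell lines also remains open.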